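Series notes: the step from compound 3 to compound 4

This account rests on a few compounds, and the source may have more. Where it says the series, first, only, none or still open, it means among the compounds named here.

Measured so far:
compound 1, `Nc1cc(N)c2nc(-c3ccccc3)c(Oc3ccc(Cl)c(Cl)c3)nc2c1`: 32400 nM
compound 2, `Nc1cc(N)c2nc(-c3ccccc3)c(NCc3ccc(F)cc3)nc2c1`: a limit of the assay, < 100000 nM
compound 3, `COc1ccc(Sc2nc3cc(N)cc(N)c3nc2-c2ccccc2)cc1`: a limit of the assay, < 100000 nM

All three were run in a functional assay on IGROV-1 cells (Homo sapiens) for inhibition, read by sulforhodamine B assay, with a stated time of 48 h; a lower number here means a stronger inhibitor of growth, a higher number a weaker inhibitor of growth. Compound 1 gives a number, 32400 nM. For compound 2 the assay reports only a limit, < 100000 nM. For compound 3 the assay likewise reports only a limit, < 100000 nM, so compound 3 stands at a limit and not at a number; one further value shown is also a limit (the limit of < 100000 nM in this assay, at which 2 of the 3 values shown sit). Accordingly the steps a step that the limit leaves unreadable from compound 1 to compound 2, a step that the limit leaves unreadable from compound 1 to compound 3 and a step that the two limits leave unreadable from compound 2 to compound 3 cannot be read in size or direction.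

Compound 4, `Nc1cc(N)c2nc(-c3ccccc3)c(Oc3ccc(F)cc3)nc2c1`, differs from compound 3 by 4-fluorophenoxy in place of (4-methoxyphenyl)sulfanyl on an aromatic carbon. Within the data shown here, no measured step gives a readable size for this change. Compound 4 shares the phenoxy attachment with compound 1, which gives a number, and carries a fluorine on that ring as compound 2 does on its benzyl ring, which gives only a limit. The expectation for compound 4 therefore rests mainly on compound 1 and its value 32400 nM. Compound 3 stands at a limit, so the expected step that the limit leaves unreadable from compound 3 to compound 4 has no readable reference point. Compound 4 is estimated at 40000 nM, within the range 15000 nM to 100000 nM.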

Compound 4, concentration for total growth inhibition: < 100000 nM
Compound 4: no number, only a limit; the forecaster's own chance of this, stated with the estimate: 35%; the middle value does not contradict the limit.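

Compound 4 gives only a limit of the assay, and its steps from compound 1, compound 2 and compound 3 cannot be read in size or direction: the limit of < 100000 nM in this assay, at which 3 of the 4 values shown sit.

The compounds shown leave open whether 4-fluorophenoxy, (4-methoxyphenyl)sulfanyl or (4-fluorobenzyl)amino on this aromatic carbon gives stronger or weaker inhibition of growth than the 3,4-dichlorophenoxy of compound 1.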